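Swapping the aryl group on compound 1: working notes

This account rests on a few compounds, and the source may have more. Where it says the series, first, only, none or still open, it means among the compounds named here.

In a functional assay on HCT-116 cells (Homo sapiens) for inhibition, read by sulforhodamine B assay, with a stated time of 48 h, tested at 50 uM (a lower number here means less inhibition of growth, a higher number more inhibition of growth at the concentration tested), compound 1 `COc1ccc([C@@H]2C/C(=N/OCc3cn(-c4ccc(O)cc4)nn3)c3cc(CC=C(C)C)c(OC)cc3O2)cc1` gives 65% at the concentration tested. Compound 3 `CCCCOc1ccc([C@@H]2CC(=O)c3cc(CC=C(C)C)c(OC)cc3O2)cc1` at 60% lies within the scatter of compound 1, while compound 2 `COc1ccc([C@@H]2C/C(=N/O)c3cc(CC=C(C)C)c(OC)cc3O2)cc1` at 47% falls beyond the scatter below compound 1. Among the measured compounds shown here, no two measured compounds differ in one place only, so the data hold no direct step for the change at hand.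

Compound 4 `COc1ccc([C@@H]2C/C(=N/OCc3cn(-c4cccc(CO)c4)nn3)c3cc(CC=C(C)C)c(OC)cc3O2)cc1` differs from compound 1 by 3-(hydroxymethyl)phenyl in place of 4-hydroxyphenyl on an aromatic nitrogen. The shared core stays untouched. For the measured compounds named here, the expectation rests on compound 1 at 65% as the only measured compound with a phenyl group on that aromatic nitrogen. The expected step of a number 5 percentage points lower from compound 1 to compound 4 (within the scatter) in this assay is a small drop that stays within the scatter, and its direction is weakly founded. Compound 4 is estimated at 60% with an expected range of 45% to 75% in this read-out.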

Compound 4, percent growth inhibition at one concentration: 27%
Compound 4: middle estimate off by 33 percentage points, on the high side; measured number outside the range, below it.
By their numbers in this assay, from the lowest: compound 4; then compound 2; then compounds 3 and 1 (each within the scatter of the next).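

In this assay the aryl group on the aromatic nitrogen of the five-membered ring proves sensitive: 3-(hydroxymethyl)phenyl in place of 4-hydroxyphenyl brings a number 38 percentage points lower from compound 1 to compound 4 (beyond the scatter) and so counts as a large step. The two groups share one six-membered aromatic ring of carbon only and the same counts of hydrogen-bond donors and acceptors, so matching these counts does not preserve the read-out in this pair. No measured evidence bears on the origin of this step.

The single swap changes both the oxygen-bearing group and its place on the ring, so the compounds shown cannot separate these two changes. Also open, from the compounds shown here alone, is how a plain phenyl, or an amine or a carboxylic acid on that ring, would read out at this position.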